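Swapping trifluoromethyl for methoxy on a shared core

The source may hold more compounds than are shown below. What is called first, only, known or untested is meant among the compounds shown, and "the series" means these compounds.

Compound 1 `C=CCc1cc(-c2ccc(C(F)(F)F)cc2)ccc1O` is the anchor here. Among the measured compounds shown here, in a functional assay on HUVEC cells (Homo sapiens) for antiproliferative activity, read by MTT assay, with a stated time of 24 h (on this read-out lower numbers stand for stronger inhibition and higher numbers for weaker inhibition), compound 1 gives 74000 nM, the only outright number among the three measured compounds. Compound 2 `C=CCc1cc(-c2cccc([N+](=O)[O-])c2)ccc1O` gives > 100000 nM in this assay, which is a limit rather than a number. Compound 3 `C=CCc1cc(-c2ccc(C(F)(F)F)cc2)ccc1OC` likewise gives > 100000 nM in this assay, again a limit. Both limits rest on (the limit of > 100000 nM in this assay, at which 2 of the 3 values shown sit). For the measured compounds named here, the single step between measured compounds, an at least 1.3-fold higher number from compound 1 to compound 3 (0.13 log units; that floor lies within the scatter), therefore fixes only a floor. Compound 4 `C=CCc1cc(-c2ccc(OC)cc2)ccc1O` differs from compound 1 by methoxy in place of trifluoromethyl on an aromatic carbon. Going by the values given here, no measured step touches this exchange, so no shift beyond the scatter is expected. The expected step is a 1.1-fold higher number from compound 1 to compound 4 (0.03 log units; within the scatter). Compound 4 is estimated at 80000 nM, within 30000 nM to 250000 nM.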

Compound 4, half-maximal inhibitory concentration: > 100000 nM
Compound 4: a limit, no number (the forecaster's own chance of this, stated with the estimate: 45%); middle value at least 1.2-fold (0.09 log units) away from the limit.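

Methoxy in place of trifluoromethyl, on this aromatic carbon para to a large group, gives an at least 1.3-fold higher number from compound 1 to compound 4 (0.13 log units; that floor lies within the scatter) in this assay, the first measured change at this position. That step is only a floor lying within the scatter, so it shows neither a real loss nor any gain. Compound 4 adds a third reading at a single limit, not a number: the limit of > 100000 nM in this assay, at which 3 of the 4 values shown sit.

From the compounds shown here alone, whether an amine or a carboxylic acid at this position would give a number under that limit stays open. So does the true distance of compound 4 from compound 1.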